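The source may report more compounds than this note shows. Statements on the series, on what has been measured and on what is new or still open speak of the compounds shown alone.

Three compounds have been measured in a functional assay on MCF cells (Homo sapiens) for antiproliferative activity, with a stated time of 72 h; on this read-out lower numbers stand for stronger inhibition and higher numbers for weaker inhibition:

- compound 1 `OC[C@H]1O[C@@H](n2cnc3c(NCc4cccc(F)c4)ncnc32)[C@H](O)[C@@H]1O`: 15300 nM
- compound 2 `OC[C@H]1O[C@@H](n2cnc3c(NCc4ccccc4Br)ncnc32)[C@H](O)[C@@H]1O`: > 166000 nM, a limit of the assay rather than a number
- compound 3 `OC[C@H]1O[C@@H](n2cnc3c(NCc4ccc(Br)cc4)ncnc32)[C@H](O)[C@@H]1O`: > 166000 nM, again a limit of the assay

Among the compounds with values here, compound 1 thus stands as the only real number in this set; the other two values sit at the limit of > 166000 nM in this assay, at which 2 of the 3 values shown sit. Compound 4 `COc1cccc(CNc2ncnc3c2ncn3[C@@H]2O[C@H](CO)[C@@H](O)[C@H]2O)c1OC` is not yet measured. Its difference from compound 1 is 2,3-dimethoxyphenyl in place of 3-fluorophenyl on a saturated chain carbon bound to a nitrogen on an aromatic ring.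

Within the data shown here, two measured steps bear on this change, since both also replace the 3-fluorophenyl of compound 1 on the same saturated chain carbon bound to a nitrogen on an aromatic ring: an at least 10-fold higher number from compound 1 to compound 2 (1.03 log units; beyond the scatter) and an at least 10-fold higher number from compound 1 to compound 3 (1.03 log units; beyond the scatter). Both times the replacement gave a large rise in the number, reaching a limit. The step from compound 2 to compound 3 cannot be read, as both values are limits. Exchanging the 3-fluorophenyl for 2,3-dimethoxyphenyl is therefore expected to weaken inhibition as well, by a step of about a 3.9-fold higher number from compound 1 to compound 4 (0.59 log units; beyond the scatter). Compound 4 is estimated at 60000 nM, within a range from 15000 nM to 200000 nM, with a fair chance that only a limit is reported.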

Compound 4, half-maximal inhibitory concentration: > 166000 nM
Compound 4: no number, only a limit; the forecaster's own chance of this, stated with the estimate: 45%; middle value at least 2.7-fold (0.44 log units) away from the limit.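

Exchanging 3-fluorophenyl for 2,3-dimethoxyphenyl on this saturated chain carbon gives an at least 10-fold higher number from compound 1 to compound 4 (1.03 log units; beyond the scatter), so the loss of inhibition in this assay is not confined to the two bromophenyl compounds, compound 2 and compound 3. All three replacements of 3-fluorophenyl shown here now end in the same way, leaving compound 1 as the only compound with a real number, and the steps among compound 2, compound 3 and compound 4 cannot be read. The assay limit caps how much can be said about these replacements: the limit of > 166000 nM in this assay, at which 3 of the 4 values shown sit.

Going by these compounds, how much weaker each of these three compounds is remains unknown, as does the order among them. On these data alone, it is also open whether a plain phenyl, a pyridyl ring or a longer chain between the ring and the nitrogen would give a measurable number.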